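The compounds below may be only part of what the source reports. "The series", "measured", "known", "first", "only" and "open" are said of these compounds alone.

Of the compounds shown here, three built on one shared core have been measured in an assay (Cricetulus griseus) for inhibition of aldehyde dehydrogenase, mitochondrial (Homo sapiens); on this read-out higher numbers stand for weaker inhibition and lower numbers for stronger inhibition. Compound 3 `CC(C)Oc1ccc2c(=O)c(-c3ccc(O)cc3)coc2c1` gives 80 nM. Compound 1 `CCOC(=O)COc1ccc2c(=O)c(-c3ccc(O)cc3)coc2c1` gives 130 nM, and compound 2 `CCCCCCC(Oc1ccc2c(=O)c(-c3ccc(O)cc3)coc2c1)C(=O)O` gives 2000 nM. Compound 3 has the lowest of these three numbers, but its gap to compound 1 lies within the scatter, so the two cannot be told apart; only compound 2 stands clearly apart, with a far higher number. Going by the values given here, the single measured step, a 1.6-fold lower number from compound 1 to compound 3 (0.21 log units; within the scatter), swaps the group on the oxygen on the aromatic ring and is itself within the scatter.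

Compound 4 `CC(Oc1ccc2c(=O)c(-c3ccc(O)cc3)coc2c1)C(=O)O` has not yet been measured. It differs from compound 3 in one place: carboxy in place of methyl on a saturated chain carbon bound to an oxygen on an aromatic ring and a saturated chain carbon. Among the compounds with values here, no measured step covers this exact change. The nearest points of reference are compound 2, which also carries a carboxy on a saturated chain carbon bound to an oxygen on an aromatic ring and gives 2000 nM, and compound 1, whose group on that oxygen gives 130 nM. As far as these compounds go, compound 2 also carries a much larger group on that carbon, so how much of its gap to compound 3 belongs to the carboxy alone is unknown. A moderate move toward a higher number is therefore expected, a 5.0-fold higher number from compound 3 to compound 4 (0.70 log units; beyond the scatter). Compound 4 is estimated at 400 nM, within 120 nM to 1500 nM.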

Compound 4, half-maximal inhibitory concentration: 2500 nM
Compound 4: middle estimate off by 6.3-fold (0.80 log units), on the low side; measured number outside the range, above it.
By their numbers in this assay, from the lowest: compounds 3 and 1 (each within the scatter of the next); then compounds 2 and 4 (each within the scatter of the next).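

In this assay, the exchange of methyl for carboxy on a saturated chain carbon bound to an oxygen on an aromatic ring produces a 31-fold higher number from compound 3 to compound 4 (1.49 log units; beyond the scatter) on its own, so the carboxy alone is enough to give a large rise with no help from a bigger group. Removing the pentyl gives a 1.3-fold higher number from compound 2 to compound 4 (0.10 log units; within the scatter) and stays within the scatter, while moving from the ester-bearing group to 1-carboxyethyl gives a 19-fold higher number from compound 1 to compound 4 (1.28 log units; beyond the scatter) as a second large step, so among these compounds the two that carry a carboxy, compound 2 and compound 4, sit together at the high end, and compound 1 and compound 3, which carry none, sit at the low end. Nothing available here explains why this change has so large an effect. As far as these compounds go, whether an ethyl ester or a primary amide in place of the carboxy on that same carbon would also give a high number remains open. All four compounds share one core, so it is also unknown whether the step keeps its size with a methoxy in place of the hydroxy on that core.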